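Swapping fluoro for dimethylsulfamoyl: one step ahead

The source may report more compounds than this note shows. Statements on the series, on what has been measured and on what is new or still open speak of the compounds shown alone.

Values so far in a physicochemical assay for lipophilicity, using the shake flask method, at pH 7.4 (on this read-out lower numbers stand for lower lipophilicity and higher numbers for higher lipophilicity), by compound:
- Compound 1 `Cc1ccc(CNC(=O)c2nc(-c3ccc(F)cc3)n(CC[C@@H](O)C[C@@H](O)CC(=O)O)c2C2CC2)cc1` gives 0.45
- Compound 2 `O=C(O)C[C@H](O)C[C@H](O)CCn1c(-c2ccc(F)cc2)nc(C(=O)NCc2ccc(F)cc2)c1C1CC1` gives 0.17
- Compound 3 `COc1ccc(CNC(=O)c2nc(-c3ccc(F)cc3)n(CC[C@@H](O)C[C@@H](O)CC(=O)O)c2C2CC2)cc1` gives 0.02

Compound 2 gives 0.17 and cannot be ranked against its two companions, since a number 0.28 log units lower from compound 1 to compound 2 (within the scatter) and a number 0.15 log units lower from compound 2 to compound 3 (within the scatter) are both small. The one clear gap in the set is a number 0.43 log units lower from compound 1 to compound 3 (beyond the scatter) and it does not involve compound 2.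

Compound 4 `CN(C)S(=O)(=O)c1ccc(CNC(=O)c2nc(-c3ccc(F)cc3)n(CC[C@@H](O)C[C@@H](O)CC(=O)O)c2C2CC2)cc1` differs from compound 2 in one place dimethylsulfamoyl in place of fluoro on an aromatic carbon and the change is dimethylsulfamoyl in place of fluoro on an aromatic carbon, para to a large group.

Among the measured compounds shown here, all three measured steps are swaps at this same carbon, so they are the only guide available. For the measured compounds named here, none of them brings in a group this large, and no measured compound carries a sulfamoyl group, so the guide is weak. Taking compound 3 as the nearest example, with a number 0.43 log units lower from compound 1 to compound 3 (beyond the scatter) as its step, a downward move is expected in this assay and it may be somewhat larger than that step.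

The expected step is a number 0.52 log units lower from compound 2 to compound 4 (beyond the scatter) and it remains only an estimate.

For compound 4 the estimated value is -0.35 with an expected range from -0.85 to 0.15 as its limits.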

Compound 4, distribution coefficient: -0.46
Estimate against measurement, compound 4: 0.11 log units above; the measured number falls inside the stated range.
By their numbers in this assay, from the lowest: compound 4; then compounds 3, 2 and 1 (each within the scatter of the next, the first and the last beyond it).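

In this assay, among the compounds shown here, dimethylsulfamoyl is the first group at this aromatic carbon that stands clear of all the others: a number 0.63 log units lower from compound 2 to compound 4 (beyond the scatter), a number 0.48 log units lower from compound 3 to compound 4 (beyond the scatter) and a number 0.91 log units lower from compound 1 to compound 4 (beyond the scatter). Among methyl, fluoro and methoxy only one pair could be told apart, whereas compound 4 has the lowest number of the four and its steps to all three others lie beyond the scatter. The swap from fluoro also brings in 6 heavy atoms in place of 1, and 2 hydrogen-bond acceptors where there were none, so in this set a much larger group at this carbon goes with a lower number, not a higher one.

No measurement here explains the drop, so which feature of the group lies behind it remains unknown. Going by these compounds, it also remains open whether the low number belongs to the sulfonyl unit itself or depends on its two methyl groups, a question that an unsubstituted sulfonamide, an amine or a carboxylic acid at this same carbon would help to answer.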